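A few compounds are considered here, and "the series" means these few. Any claim that something is new, unique, unknown or untested is made for them only; others in the source may bear on it.

Measured so far:
compound 1 `Cc1ccccc1C(=O)NN(C(=O)c1ccccc1Cl)C(C)(C)C` with 72.4 nM in an assay on cells for agonist activity at ecdysone receptor (Bombyx mori), read by a luciferase reporter, with a stated time of 24 h; on this read-out lower numbers stand for an effect already at smaller amounts and higher numbers for an effect only at larger amounts of compound
compound 2 `CC(C)(C)N(NC(=O)c1cccc(Cl)c1Cl)C(=O)c1ccccc1Cl` with 9.33 nM

Among the compounds with values here, compound 2 has the lowest of the two numbers so far; the only neighbour is compound 1, and the step of a 7.8-fold lower number from compound 1 to compound 2 (0.89 log units; beyond the scatter) lies beyond the scatter. Both share the same core; they differ only in the aryl group on the carbonyl carbon next to the amide-type nitrogen.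

Compound 3 `Cc1ccc(C(=O)NN(C(=O)c2ccccc2Cl)C(C)(C)C)cc1C` is not yet measured. It differs from compound 2 in one place: 3,4-dimethylphenyl in place of 2,3-dichlorophenyl on a carbonyl carbon. Within the data shown here, the only measured step that bears on this position is a 7.8-fold lower number from compound 1 to compound 2 (0.89 log units; beyond the scatter), which shows that exchanging a methyl-bearing phenyl for a chlorine-bearing phenyl on this carbonyl carbon gave a clearly lower number. Compound 3 moves back towards a methyl-substituted ring, though with two methyl groups at a different pattern from that of compound 1, so the change is not a plain reversal of that step. Among the measured compounds shown here, no measured compound carries a 3,4-dimethylphenyl here.

The expectation for compound 3 is therefore a number somewhat higher than that of compound 2, a step of about a 2.7-fold higher number from compound 2 to compound 3 (0.43 log units; beyond the scatter), but not as far up as compound 1. The estimated value for compound 3 is 25 nM, with a range from 6 nM to 100 nM.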

Compound 3, half-maximal effective concentration: 87.1 nM
Compound 3: the middle estimate sits 3.5-fold (0.54 log units) below what was measured; low and high end bracket the measured number.
By their numbers in this assay, from the lowest: compound 2; then compounds 1 and 3 (each within the scatter of the next).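

In this assay, the aryl group on a carbonyl carbon whose other neighbours are the amide-type nitrogen now gives a 9.3-fold higher number from compound 2 to compound 3 (0.97 log units; beyond the scatter) with 3,4-dimethylphenyl in place of 2,3-dichlorophenyl, although both groups have the same heavy-atom count, no hydrogen-bond donors or acceptors and no net charge. Within the data shown here, the two methyl-bearing groups cannot be told apart, with a 1.2-fold higher number from compound 1 to compound 3 (0.08 log units; within the scatter), so across these three compounds, with none going against it, the lower number is seen only with the chlorine-bearing 2,3-dichlorophenyl and the change in methyl pattern shows no effect beyond the scatter. Nothing available accounts for the difference between the chlorine-bearing and methyl-bearing groups at this place.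

Because the step from 2,3-dichlorophenyl to 3,4-dimethylphenyl changes both the kind of substituent and its pattern, the compounds shown do not separate these two changes; 3,4-dichlorophenyl and 2,3-dimethylphenyl would do so. They also leave open how this place responds to a ring bearing an amine or a carboxylic acid, and whether the gain seen with 2,3-dichlorophenyl persists with such groups elsewhere on the shared core.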